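N-Hydroxybutyl Extension on the Pyrrolidine Analogue

The compounds below may be only part of what the source reports. "The series", "measured", "known", "first", "only" and "open" are said of these compounds alone.

Compound 3 `c1ccc2cc(-c3noc([C@@H]4CCCN4)n3)ccc2c1` gives 34500 nM in an assay on HepG2 cells for antagonist activity at Bile acid receptor (Homo sapiens), read by a luciferase reporter (a lower number here means a stronger inhibitor, a higher number a weaker inhibitor), the highest number among the three measured compounds; compound 1 `c1ccc2cc(-c3noc(C4CCNCC4)n3)ccc2c1` gives 580 nM and compound 2 `c1ccc2cc(-c3noc([C@@H]4CCCCN4)n3)ccc2c1` gives 127 nM, so the steps of a 59-fold higher number from compound 1 to compound 3 (1.77 log units; beyond the scatter) and a 270-fold higher number from compound 2 to compound 3 (2.43 log units; beyond the scatter) are both large. Compound 4 `OCCCCN1CCC[C@H]1c1nc(-c2ccc3ccccc3c2)no1` differs from compound 3 by 4-hydroxybutyl in place of hydrogen on an amine nitrogen in a ring. For the measured compounds named here, none of the measured steps alters a substituent on the ring nitrogen; the two large steps into compound 3 concern the exchange of one ring for another, so they give context but no direction for this change. The expected step of a 2.9-fold lower number from compound 3 to compound 4 (0.46 log units; beyond the scatter) is therefore modest and uncertain. Compound 4 is estimated at 12000 nM, with a range from 2500 nM to 50000 nM.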

Compound 4, half-maximal inhibitory concentration: 33800 nM
Compound 4: middle estimate off by 2.8-fold (0.45 log units), on the low side; the range from low to high includes it.
By their numbers in this assay, from the lowest: compound 2; then compound 1; then compounds 4 and 3 (each within the scatter of the next).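

In this assay, for the compounds shown here, 4-hydroxybutyl in place of hydrogen on the ring amine nitrogen gives a 1.0-fold lower number from compound 3 to compound 4 (0.01 log units; within the scatter), the first measured step at this nitrogen. On the pyrrolidine analogue, compounds 3 and 4 therefore cannot be told apart, and this chain on this nitrogen does not separate them. Nothing available explains this result.

As far as these compounds go, whether a carboxylic acid or an amine at the end of the chain, or a shorter chain, would read the same remains open. Also open, from the compounds shown here alone, is whether 4-hydroxybutyl on the ring nitrogen of compound 2 would behave alike.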